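A few compounds are considered here, and "the series" means these few. Any claim that something is new, unique, unknown or untested is made for them only; others in the source may bear on it.

Measured in an ADME assay on MT4 cells (Homo sapiens) for cytotoxicity, read by MTT assay, with a stated time of 5 days; on this read-out higher numbers stand for lower toxicity in this test and lower numbers for higher toxicity in this test:

Compound 1 `CCOC(=O)Cn1cc(CNC(=O)c2cnc(Nc3ccc(C#N)cc3)cc2Oc2c(C)cc(C)cc2C)nn1` gives 9530 nM.
Compound 2 `Cc1cc(C)c(Oc2cc(Nc3ccc(C#N)cc3)ncc2C(=O)NCc2cn(Cc3cccc(F)c3)nn2)c(C)c1` gives >= 204000 nM, which is a limit of this assay and not a number (the limit of >= 204000 nM in this assay, at which 1 of the 3 values shown sits).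
Compound 3 `Cc1cc(C)c(Oc2cc(Nc3ccc(C#N)cc3)ncc2C(=O)NCc2cn(CCC#N)nn2)c(C)c1` gives 40200 nM.

Compound 3 holds the highest of the two numbers in this assay; its nearest neighbour is compound 1, with a 4.2-fold higher number from compound 1 to compound 3 (0.63 log units; beyond the scatter). Compound 2 sits at the limit.

Compound 4 `Cc1cc(C)c(Oc2cc(Nc3ccc(C#N)cc3)ncc2C(=O)NCc2cn(CC(=O)N3CCOCC3)nn2)c(C)c1` is not yet measured. It differs from compound 3 in one place: (morpholin-4-yl)carbonyl in place of cyanomethyl on a saturated chain carbon bound to an aromatic nitrogen.

All three measured steps turn on the same place, the saturated chain carbon bound to an aromatic nitrogen. Replacing ethoxycarbonyl there moved the number with a 4.2-fold higher number from compound 1 to compound 3 (0.63 log units; beyond the scatter) and with an at least 21-fold higher number from compound 1 to compound 2 (1.33 log units; beyond the scatter); between cyanomethyl and 3-fluorophenyl the difference reads an at least 5.0-fold lower number from compound 2 to compound 3 (0.70 log units; beyond the scatter). Among the measured compounds shown here, every change at this position so far has shifted the number beyond the scatter, in either direction, with no step from cyanomethyl to (morpholin-4-yl)carbonyl on record. For compound 4 a modest step is therefore expected in this assay, direction uncertain, as a 1.2-fold higher number from compound 3 to compound 4 (0.09 log units; within the scatter). Compound 4 is estimated at 50000 nM, within 15000 nM to 200000 nM.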

Compound 4, half-maximal cytotoxic concentration: 181000 nM
For compound 4 the middle estimate is 3.6-fold (0.56 log units) below the measured one, within the range that was stated.
By their numbers in this assay, from the lowest: compound 1; then compound 3; then compound 4. At a limit, above all of these: compound 2.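

In this assay, (morpholin-4-yl)carbonyl in place of cyanomethyl on a saturated chain carbon bound to an aromatic nitrogen gives a 4.5-fold higher number from compound 3 to compound 4 (0.65 log units; beyond the scatter), a modest step. Among the compounds shown here, the exchange of morpholin-4-yl for ethoxy on the carbonyl carbon gives a 19-fold higher number from compound 1 to compound 4 (1.28 log units; beyond the scatter), the first step at this position in which the carbonyl stays in place, and it shows that a carbonyl on this chain carbon does not by itself go with the low number of the ethoxycarbonyl compound. Compound 2 stands at a limit of this assay and not at a number: the limit of >= 204000 nM in this assay, at which 1 of the 4 values shown sits. The step that starts from this limit can be given only as a floor: an at least 1.1-fold lower number from compound 2 to compound 4 (0.05 log units; that floor lies within the scatter)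

Whether the upward step follows the morpholine ring or the amide carbonyl remains open, since the series shown holds neither a carboxylic acid nor a dimethylamino group nor a piperidine on that carbonyl carbon. Whether the number holds with a longer chain between the aromatic nitrogen and the carbonyl also stays unanswered.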